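The compounds below may be only part of what the source reports. "The series", "measured", "known", "first", "only" and "open" are said of these compounds alone.

Measured in an ADME assay on Caco-2 cells (Homo sapiens) for inhibition, read by MTT assay, with a stated time of 72 h (on this read-out lower numbers stand for stronger inhibition and higher numbers for weaker inhibition), each value a limit of the assay and not a number:
- compound 1 `CCC(C)NC(=C\C(=O)/C=C/c1ccc(O)c(OC)c1)/C=C/c1ccc(O)c(OC)c1`: > 25000 nM
- compound 2 `CC(C)CNC(=C\C(=O)/C=C/c1ccc(O)cc1)/C=C/c1ccc(O)cc1`: > 25000 nM
- compound 3 `COc1cc(/C=C/C(=O)/C=C(/C=C/c2ccc(O)c(OC)c2)NC2CCCCC2)ccc1O`: > 25000 nM

Compound 2 stands only at a limit, > 25000 nM, so no number anchors the next step. Compound 4 `O=C(/C=C(/C=C/c1ccc(O)cc1)NC1CCCCC1)/C=C/c1ccc(O)cc1` differs from it by cyclohexyl in place of isobutyl on an amine nitrogen, which is cyclohexyl in place of isobutyl on an amine nitrogen. For the measured compounds named here, the one measured step with cyclohexyl entering at this place is a step that the two limits leave unreadable from compound 1 to compound 3. Going by the values given here, the series so far offers (the limit of > 25000 nM in this assay, at which 3 of the 3 values shown sit), and no measured compound goes against this. No step beyond the scatter is therefore expected in this assay, and the estimate is a number no higher from compound 2 to compound 4 (the limit leaves the size open). The estimated value for compound 4 is 25000 nM, with an expected range of 12000 nM to 50000 nM.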

Compound 4, half-maximal inhibitory concentration: > 25000 nM
Compound 4 gave a limit, no number; the forecaster's own chance of this, stated with the estimate: 75%; the middle value lies on the limit itself.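

Compound 2 and compound 4 both give limits of the assay and not numbers, so no step can be read between them. The compounds shown leave open whether changing the amine substituent alters inhibition at all, with every value resting on one limit: the limit of > 25000 nM in this assay, at which 4 of the 4 values shown sit.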